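Removing the ethoxy group: a step toward compound 4

The source may report more compounds than this note shows. Statements on the series, on what has been measured and on what is new or still open speak of the compounds shown alone.

Of the compounds shown here, three sharing one core have been measured in a functional assay on MCF7 cells (Homo sapiens), tested at 5 uM; a lower number here means a stronger effect, a higher number a weaker effect of the compound at the concentration tested. Compound 1, with the structure `CCOc1cc(/C=C2\SC(=O)NC2=O)ccc1OCC1(C)CCc2c(C)c(OCC=C(C)C)c(C)c(C)c2O1`, gives 84%. Compound 2, with the structure `CC(C)=CCOc1c(C)c(C)c2c(c1C)CCC(C)(COc1ccc(/C=C3\SC(=O)NC3=O)cc1Br)O2`, gives 84%, while compound 3, with the structure `COc1cc(/C=C2\SC(=O)NC2=O)ccc1OCC1(C)CCc2c(C)c(OCC=C(C)C)c(C)c(C)c2O1`, gives 78%. Compound 1 and compound 2 stand level, and together they hold the highest of the three numbers; compound 3 lies furthest from compound 1, though only by a number 6 percentage points lower from compound 1 to compound 3 (within the scatter).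

Compound 4, with the structure `CC(C)=CCOc1c(C)c(C)c2c(c1C)CCC(C)(COc1ccc(/C=C3\SC(=O)NC3=O)cc1)O2`, is not yet measured. It differs from compound 1 in one place: hydrogen in place of ethoxy on an aromatic carbon.

The measured steps that bear on this change all alter the same position: no change at the digits printed from compound 1 to compound 2 (within the scatter) and a number 6 percentage points lower from compound 1 to compound 3 (within the scatter), as well as a number 6 percentage points lower from compound 2 to compound 3 (within the scatter). None of them moved the read-out beyond the scatter, so no step beyond the scatter is expected here either, perhaps a slight drift downward. The expected step is a number 3 percentage points lower from compound 1 to compound 4 (within the scatter), giving an estimate for compound 4 of 81%, within a range from 68% to 92%.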

Compound 4, a percentage reported as activity, at one concentration (the size of the read-out at that concentration, not a potency): 21%
For compound 4 the middle estimate is 60 percentage points above the measured one, and the stated range ends above it.
By their numbers in this assay, from the lowest: compound 4; then compounds 3, 1 and 2 (each within the scatter of the next).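

In this assay, ethoxy, methoxy and bromo on this aromatic carbon all read within the scatter of one another, but with hydrogen there the result is a number 63 percentage points lower from compound 1 to compound 4 (beyond the scatter) and also a number 57 percentage points lower from compound 3 to compound 4 (beyond the scatter) and a number 63 percentage points lower from compound 2 to compound 4 (beyond the scatter) in a large step each. The position is therefore far from indifferent: three quite different groups give the same weak effect, while compound 4, with no group there at all, gives a clearly stronger effect than each of them at this concentration. No measurement here offers an explanation for this sharp difference between hydrogen and the three groups.

As far as these compounds go, whether a fluorine, a hydroxyl or an amine on this carbon would behave like hydrogen or like ethoxy stays open. From the compounds shown here alone, a read-out at one concentration is also not a potency, so how far compound 4 truly outperforms the others remains unknown.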